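Tolerated concentration: from compound 2 to compound 3

The source may hold more compounds than are shown below. What is called first, only, known or untested is meant among the compounds shown, and "the series" means these compounds.

Compound 1 `CCN(C)c1nc(Cc2c(F)cccc2F)c(C)c(=O)[nH]1` gives > 85000 nM as a limit
Compound 2 `Cc1c(C(C)c2c(F)cccc2F)nc(N(C)C)[nH]c1=O` gives > 17000 nM as a limit

In an ADME assay on MT4 cells (Homo sapiens) for cytotoxicity, read by MTT assay, with a stated time of 4 days (a lower number here means that less compound is tolerated, a higher number that more compound is tolerated), compound 2 gives > 17000 nM as a limit and not a number. For the measured compounds named here, the only other value, that of compound 1, is also a limit. Compound 2 therefore has no measured number to be placed against, and no order between the two compounds can be read.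

Compound 3 `CCN(C)c1nc(C(C)c2c(F)cccc2F)c(C)c(=O)[nH]1` has not yet been measured. It carries methyl in place of hydrogen on a saturated chain carbon bound to a nitrogen on an aromatic ring and so dimethylamino becomes ethyl(methyl)amino. Going by the values given here, the series holds no step between measured compounds that could size this change. In this assay no step beyond the scatter is expected. The expected shift is a step that the limit leaves unreadable from compound 2 to compound 3 and this estimate is taken against a limit. For compound 3 the estimated value is 25000 nM with 10000 nM to 90000 nM as the expected range. A report as a limit is again expected to be the likely outcome.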

Compound 3, half-maximal cytotoxic concentration: 81000 nM
Beside the measured number, compound 3's estimate is 3.2-fold (0.51 log units) below it; the measured number falls inside the stated range.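

In this assay, for the compounds shown here, compound 3 gives the first actual number of the series, 81000 nM, so the tolerated concentration of a compound carrying both the methyl on the saturated chain carbon bound to two aromatic carbons and the ethyl(methyl)amino group can now be stated rather than bounded. Methyl in place of hydrogen at that chain carbon gives an at least 1.0-fold lower number from compound 1 to compound 3 (0.02 log units; that floor lies within the scatter); the start of this step is a limit, so the true size stays unknown, and what can be read does not separate the two compounds. The change from dimethylamino to ethyl(methyl)amino cannot be read as a step, and compound 2 remains a limit of the assay: the limit of > 17000 nM in this assay, at which 1 of the 3 values shown sits.

From the compounds shown here alone, whether the chain carbon would tolerate a longer chain such as ethyl, or a hydroxyl in place of the methyl, stays open. Also open, going by these compounds, is how a cyclic amine such as pyrrolidine in place of ethyl(methyl)amino would behave in this assay, and sizing either step would take actual numbers for the two compounds now held as limits.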